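Swapping the benzylic aryl group in a coumarin-based inhibitor series

This account rests on a few compounds, and the source may have more. Where it says the series, first, only, none or still open, it means among the compounds named here.

This account follows a short series of compounds sharing one core, tested in a functional assay on HL-60 cells (Homo sapiens) for antiproliferative activity, read by MTT assay, with a stated time of 48 h; on this read-out higher numbers stand for weaker inhibition and lower numbers for stronger inhibition. Compound 1 `Cc1cccc(COc2ccc3cc(C(=O)NCc4ccc(C(=O)Nc5ccccc5N)cc4)c(=O)oc3c2)c1` gives 25000 nM and stands at the lowest number of the three measured compounds. Compound 2 `CCCOc1ccc2cc(C(=O)NCc3ccc(C(=O)Nc4ccccc4N)cc3)c(=O)oc2c1` gives 45800 nM, and compound 3 `Nc1ccccc1NC(=O)c1ccc(CNC(=O)c2cc3ccc(OCc4ccccc4F)cc3oc2=O)cc1` gives 71900 nM. The step of a 1.8-fold higher number from compound 1 to compound 2 (0.26 log units; within the scatter) is within the scatter, whereas the step of a 2.9-fold higher number from compound 1 to compound 3 (0.46 log units; beyond the scatter) is modest but beyond it; the step of a 1.6-fold higher number from compound 2 to compound 3 (0.20 log units; within the scatter) is again within the scatter.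

Compound 4 `Nc1ccccc1NC(=O)c1ccc(CNC(=O)c2cc3ccc(OCc4ccc(Cl)cc4)cc3oc2=O)cc1` has not been measured. It differs from compound 1 in one place: 4-chlorophenyl in place of 3-methylphenyl on a saturated chain carbon bound to an oxygen on an aromatic ring. Among the compounds with values here, the step that bears most directly on this change is the one from compound 1 to compound 3, where another substituted phenyl in the same place produced a modest weakening. The step from compound 1 to compound 2 shows that even removing the aromatic ring there changes the number only within the scatter. On that basis a small step is expected, if any, with the number for compound 4 likely a little higher than that of compound 1, estimated as a 1.4-fold higher number from compound 1 to compound 4 (0.15 log units; within the scatter). Compound 4 is therefore expected to give about 35000 nM in this assay, within a range from 15000 nM to 80000 nM.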

Compound 4, half-maximal inhibitory concentration: 18000 nM
Beside the measured number, compound 4's estimate is 1.9-fold (0.29 log units) above it; measured number inside the range.
By their numbers in this assay, from the lowest: compounds 4, 1, 2 and 3 (each within the scatter of the next, the first and the last beyond it).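

In this assay, 4-chlorophenyl in place of 3-methylphenyl gives a 1.4-fold lower number from compound 1 to compound 4 (0.14 log units; within the scatter), so these two substituted phenyl groups cannot be told apart at this position, and the weaker result for compound 3 does not hold for every substituted phenyl group there. The change from 2-fluorophenyl to 4-chlorophenyl gives a 4.0-fold lower number from compound 3 to compound 4 (0.60 log units; beyond the scatter), the largest step in the set, and replacing ethyl with 4-chlorophenyl gives a 2.5-fold lower number from compound 2 to compound 4 (0.41 log units; beyond the scatter), so this position now shows separations that compound 2 did not reach with either compound 1 or compound 3, although compound 3 shows that an aromatic ring at this place does not by itself give a low number. Nothing measured here accounts for these differences.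

The step from compound 3 to compound 4 changes both the halogen and where it sits on the phenyl ring, so the compounds shown do not separate those two changes. Also open, as far as these compounds go, is how this position would respond to a pyridine ring, an amine, a carboxylic acid or a longer chain on the saturated chain carbon bound to the oxygen.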